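A Halogen Swap on the Phenyl Ring of Compound 2

The source may report more compounds than this note shows. Statements on the series, on what has been measured and on what is new or still open speak of the compounds shown alone.

Compound 1 `CN1CCN(c2nc(N)nc(Cc3cccc(Cl)c3)n2)CC1` gives 28 nM in an assay on HEK293 cells for displacement of a labelled ligand from 5-hydroxytryptamine receptor 6 (Homo sapiens); on this read-out lower numbers stand for stronger inhibition and higher numbers for weaker inhibition.
Compound 2 `CN1CCN(c2nc(N)nc(Cc3ccc(Cl)cc3)n2)CC1` gives 52 nM in this assay.
Compound 3 `CN1CCN(c2nc(N)nc(Cc3ccc(Cl)c(Cl)c3)n2)CC1` gives 32 nM in this assay.

Compound 2 has the highest of these three numbers, but the gaps are small: a 1.9-fold higher number from compound 1 to compound 2 (0.27 log units; within the scatter), and a 1.6-fold lower number from compound 2 to compound 3 (0.21 log units; within the scatter). All three compounds share the same core and differ only in the halogens on the phenyl ring, and none of those differences moved the number beyond the scatter.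

Compound 4 `CN1CCN(c2nc(N)nc(Cc3ccccc3F)n2)CC1` is not yet measured. It differs from compound 2 in one place: 2-fluorophenyl in place of 4-chlorophenyl on a saturated chain carbon bound to an aromatic carbon. Going by the values given here, the steps that bear on this are the ones that already altered this phenyl ring: exchanging 3-chlorophenyl for 4-chlorophenyl, a 1.9-fold higher number from compound 1 to compound 2 (0.27 log units; within the scatter), and adding a chloro, a 1.1-fold higher number from compound 1 to compound 3 (0.06 log units; within the scatter). Since every such change stayed within the scatter, no step beyond the scatter is expected from compound 2 to compound 4 either, in this assay: a 1.3-fold lower number from compound 2 to compound 4 (0.11 log units; within the scatter). Compound 4 is therefore estimated at 40 nM, with an expected range from 15 nM to 120 nM.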

Compound 4, inhibition constant: 88 nM
Compound 4: middle estimate off by 2.2-fold (0.34 log units), on the low side; measured number inside the range.
By their numbers in this assay, from the lowest: compounds 1, 3, 2 and 4 (each within the scatter of the next, the first and the last beyond it).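

The step of a 1.7-fold higher number from compound 2 to compound 4 (0.23 log units; within the scatter) shows that in this assay even a swap of both the halogen and its place on the phenyl ring can stay within the scatter. Going by these compounds alone, the comparison with the other monochloro compound gives a different reading: the step of a 3.1-fold higher number from compound 1 to compound 4 (0.50 log units; beyond the scatter) is the first change at this position to pass beyond the scatter, though only modestly, so what this ring carries can matter to a small degree. No measurement shown here explains this difference.

Each 2-fluorophenyl step changes the halogen and its place together, and these compounds do not separate those two changes. Also open, as far as these compounds go, is how the number would respond to an amine on this ring, or to a longer chain linking the ring to the shared core.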